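The compounds below may be only part of what the source reports. "The series", "measured", "known", "first", "only" and "open" are said of these compounds alone.

In a physicochemical assay for solubility, in phosphate buffer, measured as kinetic solubility, at pH 7.4 (a lower number here means a less soluble compound, a higher number a more soluble compound), compound 1 (`Cc1oc(-c2ccc(Cl)cc2)nc1CN1CCC(C(=O)NCCCN2C[C@H](C)C[C@H](C)C2)CC1`) reads > 72 ug/mL as a limit of the assay and not as a number. Compound 2 (`Cc1oc(-c2c(Cl)cccc2C(F)(F)F)nc1CN1CCC(C(=O)NCCCN2C[C@H](C)C[C@H](C)C2)CC1`) gives 65.1 ug/mL and compound 3 (`CCc1ccccc1-c1nc(CN2CCC(C(=O)NCCCN3C[C@H](C)C[C@H](C)C3)CC2)c(C)o1`) gives 55.9 ug/mL in the same read-out. Between these two stands a 1.2-fold lower number from compound 2 to compound 3 (0.07 log units; within the scatter) as the only step with two numbers, so compound 3 sits level with compound 2. Within the data shown here, compound 4 (`Cc1cccc(C)c1-c1nc(CN2CCC(C(=O)NCCCN3C[C@H](C)C[C@H](C)C3)CC2)c(C)o1`) carries 2,6-dimethylphenyl in place of 2-ethylphenyl on an aromatic carbon as its one change, 2,6-dimethylphenyl in place of 2-ethylphenyl on an aromatic carbon. The other swaps at that carbon, an at least 1.1-fold lower number from compound 1 to compound 2 (0.04 log units; that floor lies within the scatter) and an at least 1.2-fold lower number from compound 1 to compound 3 (0.10 log units; that floor lies within the scatter) as well, start from the limit (the limit of > 72 ug/mL in this assay, at which 1 of the 3 values shown sits) and show only floors within the scatter. Resting on compound 3 at 55.9 ug/mL and on those small steps, the expected step in this assay is a 1.0-fold higher number from compound 3 to compound 4 (0.02 log units; within the scatter) and nothing beyond the scatter. For compound 4 the estimate is 58 ug/mL with an expected range from 38 ug/mL to 78 ug/mL in this read-out.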

Compound 4, solubility: 55.9 ug/mL
The estimate for compound 4 lay 1.0-fold (0.02 log units) above the measured number; the measured number falls inside the stated range.
By their numbers in this assay, from the lowest: compounds 3, 4 and 2 (each within the scatter of the next). At a limit, above all of these: compound 1.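

In this assay, 2,6-dimethylphenyl in place of 2-ethylphenyl, the same atoms joined differently, gives no change at the digits printed from compound 3 to compound 4 (within the scatter). Set against the chlorinated group, it gives a 1.2-fold lower number from compound 2 to compound 4 (0.07 log units; within the scatter), so compound 2, compound 3 and compound 4 read level at this aromatic carbon. The step from the limit gives only a floor, an at least 1.2-fold lower number from compound 1 to compound 4 (0.10 log units; that floor lies within the scatter): the limit of > 72 ug/mL in this assay, at which 1 of the 4 values shown sits.

The compounds shown leave open how far 4-chlorophenyl truly stands from the other groups. They also leave open whether a pyridine ring or a phenyl bearing a carboxylic acid at this carbon would move the number beyond the scatter.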